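Methoxy in place of nitro on a dianilinopyrimidine scaffold

The source may hold more compounds than are shown below. What is called first, only, known or untested is meant among the compounds shown, and "the series" means these compounds.

Compound 1 `Cc1cnc(Nc2ccc([N+](=O)[O-])cc2)nc1Nc1nc2ccccc2s1` was tested in a functional assay on MDA-MB-231 cells (Homo sapiens) for antiproliferative activity, read by MTT assay, with a stated time of 48 h (on this read-out higher numbers stand for weaker inhibition and lower numbers for stronger inhibition), and gave 22500 nM. Going by the values given here, of the two compounds measured so far, compound 1 has the higher number: the second compound, compound 2 `CS(=O)(=O)c1ccc(Nc2ncc(F)c(Nc3nc4ccc(F)cc4s3)n2)cc1`, gave 8900 nM in this assay, and the gap between the two values is said to lie beyond the usual scatter, so compound 1 is the weaker inhibitor of the pair. Compound 2 differs from compound 1 at several positions at once, so the two values alone cannot be traced to any single change.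

The next compound, compound 3 `COc1ccc(Nc2ncc(C)c(Nc3nc4ccccc4s3)n2)cc1`, differs from compound 1 in one place only: methoxy in place of nitro on an aromatic carbon. Among the compounds with values here, no single-point step between measured compounds is available to anchor the expected size of this change, so the expectation rests on compound 1 alone. A modest downward movement, toward stronger inhibition, is expected, but not clearly beyond the scatter: the step from compound 1 to compound 3 in this assay is estimated as a 1.5-fold lower number from compound 1 to compound 3 (0.18 log units; within the scatter). For compound 3 the estimated value in this assay is 15000 nM, within a range from 5000 nM to 45000 nM.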

Compound 3, half-maximal inhibitory concentration: > 50000 nM
Compound 3 gave a limit, no number; the forecaster's own chance of this, stated with the estimate: 10%; middle value at least 3.3-fold (0.52 log units) away from the limit.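

Going by these compounds alone, at the place para to a large group, on the six-membered aromatic ring of carbon only, the change from 4-nitrophenyl to 4-methoxyphenyl gives the first one-place step in this assay, and it runs toward weaker inhibition, with an at least 2.2-fold higher number from compound 1 to compound 3 (0.34 log units; beyond the scatter). For compound 3 the read-out is a limit of the assay and not a number: the limit of > 50000 nM in this assay, at which 1 of the 3 values shown sits. Compound 1 keeps a measured value while its methoxy counterpart does not, so with the rest of the molecule unchanged, the group at this place clearly matters for the read-out, and methoxy cannot stand in for nitro here without a loss.

From the compounds shown here alone, whether an amine, a nitrile or a carboxylic acid at this place would read closer to compound 1 or to compound 3 stays open, as does the true size of the step, which the limit leaves without an upper end. Also open, going by these compounds, is whether the same change would have a similar effect on the core of compound 2.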